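Removing a Methyl Group from a Pyrazole Anilinomethyl Series

A few compounds are considered here, and "the series" means these few. Any claim that something is new, unique, unknown or untested is made for them only; others in the source may bear on it.

Three compounds share one core, all carrying a bromophenyl group and a phenyl group on the same heterocycle, with an aromatic amine attached through a methylene bridge. Compound 1 is `Clc1ccc(NCc2cn(-c3ccccc3)nc2-c2ccc(Br)cc2)cc1`, in which the amine bears a chloro substituent. Compound 2 is `Cc1ccc(NCc2cn(-c3ccccc3)nc2-c2ccc(Br)cc2)cc1`, in which a methyl group takes that place. Compound 3, `Brc1ccc(-c2nn(-c3ccccc3)cc2CNc2ccccc2)cc1`, carries neither.

In an ADME assay on MDBK cells (Bos taurus) for cytotoxicity, read by MTT assay, with a stated time of 72 h (a lower number here means that less compound is tolerated, a higher number that more compound is tolerated), compound 1 gives > 100000 nM; > 100000 nM (2 entries), and this is a limit of the assay rather than a measured number. In this assay compound 2 gives > 100000 nM, which is also a limit and not a number. Compound 2 therefore stands where nothing more than a boundary is known: its tolerance lies beyond the highest concentration tested, as described by the limit of > 100000 nM in this assay, at which 1 of the 2 values shown sits.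

The change from compound 2 to compound 3 is hydrogen in place of methyl on an aromatic carbon. Among the measured compounds shown here, no measured step is available to calibrate how such a change behaves in this assay, so the expected step from compound 2 to compound 3, a number no higher from compound 2 to compound 3 (the limit leaves the size open), is estimated as none beyond the usual scatter. Compound 3 is accordingly estimated at 100000 nM in this assay, within a range from 50000 nM to 200000 nM.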

Compound 3, half-maximal cytotoxic concentration: > 100000 nM
Compound 3 ended at the assay's limit; the forecaster's own chance of this, stated with the estimate: 80%; the middle value lies on the limit itself.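

Compound 2 and compound 3 both stop at the same limit, so no step can be read between them and the change from methyl to hydrogen gets no size: the limit of > 100000 nM in this assay, at which 2 of the 3 values shown sit.

The compounds shown leave open how much of compound 1, compound 2 or compound 3 it takes to reach a half-maximal cytotoxic effect in this assay.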